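This account rests on a few compounds, and the source may have more. Where it says the series, first, only, none or still open, it means among the compounds named here.

Measured in a functional assay with Homo sapiens as the target; on this read-out higher numbers stand for weaker inhibition and lower numbers for stronger inhibition:
- Compound 1 `CC(C)[C@H](NC(=O)COc1cccc2ccccc12)C(=O)N[C@@H](CC(=O)O)C(=O)COc1ccccc1C(F)(F)F`: 17300 nM
- Compound 2 `CC(C)[C@H](NC(=O)COc1cccc2ccccc12)C(=O)N[C@@H](CC(=O)O)C(=O)COc1ccc(F)cc1F`: 17600 nM

For the measured compounds named here, the value of compound 2 lies within the scatter of the only other measured value, that of compound 1, so the two stand level. Compound 3 `CC(C)[C@H](NC(=O)COc1cccc2ccccc12)C(=O)N[C@@H](CC(=O)O)C(=O)COc1c(F)cc(F)cc1F` differs from compound 2 by one change, fluoro in place of hydrogen on an aromatic carbon, which turns 2,4-difluorophenoxy into 2,4,6-trifluorophenoxy. The new fluoro stands ortho to a large group and meta to two fluoro groups. Going by the values given here, one measured step bears on this, as it changes the same aromatic group: a 1.0-fold higher number from compound 1 to compound 2 (0.01 log units; within the scatter). Two compounds are thin evidence, but no step beyond the scatter is expected in this assay. The expected change is a 1.1-fold lower number from compound 2 to compound 3 (0.04 log units; within the scatter). For compound 3 the estimated value is 16000 nM, with an expected range of 7000 nM to 35000 nM.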

Compound 3, half-maximal inhibitory concentration: 14900 nM
The estimate for compound 3 lay 1.1-fold (0.03 log units) above the measured number; the range from low to high includes it.
By their numbers in this assay, from the lowest: compounds 3, 1 and 2 (each within the scatter of the next).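

In this assay the added fluoro, on an aromatic carbon ortho to a large group and meta to two fluoro groups, produces no step beyond the scatter (a 1.2-fold lower number from compound 2 to compound 3 (0.07 log units; within the scatter)). The 2,4,6-trifluorophenyl group also stands level with the 2-(trifluoromethyl)phenyl group (a 1.2-fold lower number from compound 1 to compound 3 (0.06 log units; within the scatter)), so all three fluorinated aryl groups on this oxygen give equivalent numbers, and this position tolerates a third fluoro without a measurable step. Nothing at hand explains why these groups stand level.

From the compounds shown here alone, whether a different kind of substituent on this ring, such as an amine, a carboxylic acid or a nitrile, would move the number beyond the scatter remains open. So does the effect of replacing the aryl group on this oxygen with a longer chain.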